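Moving a tert-butyl to neopentyl in a second core

The source may report more compounds than this note shows. Statements on the series, on what has been measured and on what is new or still open speak of the compounds shown alone.

In an ADME assay on liver for metabolic stability, with Liver microsome (Homo sapiens) as the target, read by LC-MS, using microsomes (a higher number here means faster removal of the compound, a lower number slower removal), compound 2 `CC(C)(C)[C@@H](O)C(=O)N1N=CC[C@H]1C(=O)NCc1cc(Cl)ccc1-n1cnnn1` gives only a limit of the assay, < 12 mL.min-1.g-1. Compound 1 `CC(C)(C)C[C@@H](O)C(=O)N1N=CC[C@H]1C(=O)NCc1cc(Cl)ccc1-n1cnnn1` gives 22 mL.min-1.g-1 in this assay. Between them the change is neopentyl in place of tert-butyl on a saturated chain carbon bound to a carbonyl carbon and an oxygen on a saturated carbon, and it brings an at least 1.8-fold higher number from compound 2 to compound 1 (0.26 log units; that floor lies within the scatter). Compound 3 `CC(C)(C)[C@@H](O)C(=O)N1NCC[C@H]1C(=O)NCc1cc(Cl)ccc1-n1cnnn1` carries a different core; how that core differs from the core of compound 2 is not broken down here. In this assay compound 3 gives 15 mL.min-1.g-1. Compound 4 `CC(C)(C)C[C@@H](O)C(=O)N1NCC[C@H]1C(=O)NCc1cc(Cl)ccc1-n1cnnn1` is not yet measured; it differs from compound 3 by neopentyl in place of tert-butyl on a saturated chain carbon bound to a carbonyl carbon and an oxygen on a saturated carbon, the same change seen between compound 2 and compound 1. A similar modest rise is expected, about a 1.7-fold higher number from compound 3 to compound 4 (0.22 log units; within the scatter), resting on an at least 1.8-fold higher number from compound 2 to compound 1 (0.26 log units; that floor lies within the scatter). Compound 4 is therefore expected to give 25 mL.min-1.g-1, most likely between 12 mL.min-1.g-1 and 50 mL.min-1.g-1.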

Compound 4, intrinsic clearance in microsomes: 25 mL.min-1.g-1
Beside the measured number, compound 4's estimate shows no gap at the digits printed; the measured number falls inside the stated range.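

In this assay, neopentyl in place of tert-butyl on the second core brings a 1.7-fold higher number from compound 3 to compound 4 (0.22 log units; within the scatter). Both steps point the same way, which fits a change that carries from one core to the other, but neither is shown to lie beyond the usual scatter, so this does not establish a real effect on either core, nor an equal one on both: the same change on two cores in this assay, an at least 1.8-fold higher number (0.26 log units; that floor lies within the scatter) from compound 2 to compound 1 and a 1.7-fold higher number (0.22 log units; within the scatter) from compound 3 to compound 4; the limit leaves it open whether they differ Compound 2 gives only a limit of the assay, so the first step has no exact size: the limit of < 12 mL.min-1.g-1 in this assay, at which 1 of the 4 values shown sits.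

The compounds shown leave open whether the same pattern holds on any further core. They also leave open how a longer chain or an amine would compare at this place, on a saturated chain carbon bound to a carbonyl carbon and an oxygen on a saturated carbon.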